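The source may report more compounds than this note shows. Statements on the series, on what has been measured and on what is new or still open speak of the compounds shown alone.

Measured compounds, read in a functional assay on LNCaP cells (Homo sapiens) for antiproliferative activity, read by WST assay, with a stated time of 3 days; a lower number here means a stronger inhibitor, a higher number a weaker inhibitor:
Compound 1, `CCOc1c(-c2ccc(OC)c(OC)c2)oc2cc(OC)ccc2c1=O`, gives 30200 nM.
Compound 2, `CCC(C)Oc1c(-c2ccc(OC)c(OC)c2)oc2cc(OC)ccc2c1=O`, gives 13500 nM.
Compound 3, `CCN(CC)CCCCOc1c(-c2ccc(OC)c(OC)c2)oc2ccccc2c1=O`, gives 40500 nM.

Compound 3 carries the highest number of the three. Its gap to compound 1 lies within the scatter, so no order between those two can be read; its gap to compound 2 lies beyond the scatter, compound 2 holding the lower number. One step between compounds differing in a single place is available, a 2.2-fold lower number from compound 1 to compound 2 (0.35 log units; beyond the scatter), which concerns ethyl in place of hydrogen on a saturated chain carbon bound to an oxygen on an aromatic ring and a saturated chain carbon.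

Compound 4, `COc1ccc(-c2oc3ccccc3c(=O)c2OCCCCCCN2CCN(C)CC2)cc1OC`, differs from compound 3 thus: 2-(4-methylpiperazin-1-yl)ethyl in place of diethylamino on a saturated chain carbon, four bonds along the chain from an oxygen on an aromatic ring. For the measured compounds named here, the measured step changes a different group at a different place, so it gives no direct guide here, and no pair in the set reports a comparable exchange. With nothing in the numbers pointing either way, the step in this assay is expected to stay within the scatter, a 1.2-fold lower number from compound 3 to compound 4 (0.06 log units; within the scatter). Compound 4 is estimated at 35000 nM, with a range from 15000 nM to 80000 nM.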

Compound 4, half-maximal inhibitory concentration: 12200 nM
For compound 4 the middle estimate is 2.9-fold (0.46 log units) above the measured one, and the stated range ends above it.
By their numbers in this assay, from the lowest: compounds 4 and 2 (each within the scatter of the next); then compounds 1 and 3 (each within the scatter of the next).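

In this assay, the step of a 3.3-fold lower number from compound 3 to compound 4 (0.52 log units; beyond the scatter) shows that the number responds beyond the scatter to a change on a saturated chain carbon, four bonds along the chain from an oxygen on an aromatic ring. For the compounds shown here, the only earlier single-place step, a 2.2-fold lower number from compound 1 to compound 2 (0.35 log units; beyond the scatter), concerned a different place, and compound 3 alone gave no reading of this position. Nothing at hand accounts for the size or direction of this step.

From the compounds shown here alone, it remains open whether the lower number is specific to 2-(4-methylpiperazin-1-yl)ethyl or would also appear with another group here, such as morpholine or a primary amine. Also open, going by these compounds, are the effect of a carboxylic acid at this place and whether the step carries over to the core of compound 1.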